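Hydroxy step on compound 1 in growth inhibition

The source may report more compounds than this note shows. Statements on the series, on what has been measured and on what is new or still open speak of the compounds shown alone.

compound 1 `COc1ccc2c(c1)CCCC(c1cc(OC)c(OC)c(OC)c1)=C2`: 550 nM
compound 2 `COc1ccc2c(c1)CCCC=C2c1cc(OC)c(OC)c(OC)c1`: 27 nM

In a functional assay on DU-145 cells (Homo sapiens) for inhibition, read by sulforhodamine B assay, with a stated time of 48 h (a lower number here means a stronger inhibitor of growth, a higher number a weaker inhibitor of growth), compound 1 at 550 nM holds the higher of the two numbers. Compound 2 gives 27 nM. The gap between these two compounds lies beyond the scatter. Compound 3 `COc1ccc2c(c1O)CCCC(c1cc(OC)c(OC)c(OC)c1)=C2` changes the core of compound 1 by hydroxy in place of hydrogen on an aromatic carbon, ortho to a methoxy group. For the measured compounds named here, no measured pair shows this change, so the expectation remains loose. A moderate shift toward stronger inhibition, beyond the scatter, is expected, with an estimated 3.7-fold lower number from compound 1 to compound 3 (0.56 log units; beyond the scatter). Compound 3 is estimated at 150 nM, with an expected range of 25 nM to 800 nM.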

Compound 3, concentration for 50% growth inhibition: 440 nM
Estimate against measurement, compound 3: 2.9-fold (0.47 log units) below; measured number inside the range.
By their numbers in this assay, from the lowest: compound 2; then compounds 3 and 1 (each within the scatter of the next).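

In this assay, hydroxy in place of hydrogen on an aromatic carbon, ortho to a methoxy group, gives a 1.3-fold lower number from compound 1 to compound 3 (0.10 log units; within the scatter) and so leaves growth inhibition on the core of compound 1 without a readable change. This position therefore tolerates the added hydroxy on this core. Nothing available explains this flat step.

From the compounds shown here alone, whether an amine or a fluorine atom on the same aromatic carbon would shift the number remains open. So does whether the same hydroxy step would hold on the core of compound 2.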